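The compounds below may be only part of what the source reports. "The series", "measured", "known", "first", "only" and "open" are said of these compounds alone.

Working notes on the series. Compound 1 `Cc1ccc(-c2cc(C(=O)N3CCC4(CC3)CC(=O)c3nn(C(C)(C)C)cc3O4)c3ccccc3n2)cc1` gives 1440 nM in a functional assay on HepG2 cells (Homo sapiens) for inhibition, read by MTT assay, with a stated time of 72 h; on this read-out lower numbers stand for stronger inhibition and higher numbers for weaker inhibition. Compound 2 `CC(C)(C)n1cc2c(n1)C(=O)CC1(CCN(C(=O)c3cc(-c4ccc(Cl)cc4)nc4ccccc34)CC1)O2` gives 630 nM, and compound 3 `CC(C)(C)n1cc2c(n1)C(=O)CC1(CCN(C(=O)c3cc(-c4ccc(N)cc4)nc4ccccc34)CC1)O2` gives 630 nM. On these numbers compound 2 sits level with compound 3 at the digits shown, the two together at the low end of the three values; the step from compound 1 is a 2.3-fold lower number from compound 1 to compound 2 (0.36 log units; beyond the scatter), while no change at the digits printed from compound 2 to compound 3 (within the scatter).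

Compound 4 `Cc1cc(C(=O)N2CCC3(CC2)CC(=O)c2nn(C(C)(C)C)cc2O3)c2ccccc2n1` has not yet been measured. Its change from compound 2 is methyl in place of 4-chlorophenyl on an aromatic carbon. Going by the values given here, none of the measured steps covers this kind of change: a 2.3-fold lower number from compound 1 to compound 2 (0.36 log units; beyond the scatter) and a 2.3-fold lower number from compound 1 to compound 3 (0.36 log units; beyond the scatter) swap one group for another on the phenyl ring that is kept, and no change at the digits printed from compound 2 to compound 3 (within the scatter) does the same. The measured steps therefore speak only to how substituent swaps on that ring move the number, all modest or within the scatter, and say nothing about removing the ring itself. For compound 4 the expectation is a weaker result, with wide uncertainty: the number is estimated at 3000 nM, within 600 nM to 15000 nM. The expected step is a 4.8-fold higher number from compound 2 to compound 4 (0.68 log units; beyond the scatter).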

Compound 4, half-maximal inhibitory concentration: 9480 nM
Compound 4: the middle estimate sits 3.2-fold (0.50 log units) below what was measured; low and high end bracket the measured number.
By their numbers in this assay, from the lowest: compounds 2 and 3 (each within the scatter of the next); then compound 1; then compound 4.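

In this assay, the aryl group on this aromatic carbon next to the ring nitrogen proves to matter far more than the substituent it carries: replacing it with methyl gives large steps (a 15-fold higher number from compound 2 to compound 4 (1.18 log units; beyond the scatter)) and (a 15-fold higher number from compound 3 to compound 4 (1.18 log units; beyond the scatter)), and a modest one (a 6.6-fold higher number from compound 1 to compound 4 (0.82 log units; beyond the scatter)). All three steps run the same way, so compounds 1, 2 and 3 each give a lower number than compound 4, and removing the ring moves the number further than any swap among chloro, amino and methyl on it. No measurement at hand accounts for this loss, so only its size is on record.

As far as these compounds go, whether a ring at this position is required remains open, since a cyclohexyl or pyridyl ring, or a longer chain such as butyl, would test this. From the compounds shown here alone, it also remains open whether a carboxylic acid or methoxy on the phenyl ring would move the number further than chloro or amino.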